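A few compounds are considered here, and "the series" means these few. Any claim that something is new, unique, unknown or untested is made for them only; others in the source may bear on it.

Compound 1 `Cn1ncc2c(=O)n(-c3ccccc3)c(COc3cccc(F)c3)nc21` gives 8200 nM in an assay on isolated protein for inhibition of aldehyde dehydrogenase 1A1 (Homo sapiens); a higher number here means a weaker inhibitor, a lower number a stronger inhibitor. Compound 2 `CC(Sc1nc2c(cnn2C)c(=O)n1-c1ccc(CCO)cc1)c1ccccc1` gives 360 nM in this assay, the lower of the two numbers, and its gap to compound 1 is beyond the scatter. Compound 3 `CC(Sc1nc2c(cnn2C)c(=O)n1-c1ccc(CO)cc1)c1ccccc1` has not yet been measured. It differs from compound 2 by hydroxy in place of hydroxymethyl on a saturated chain carbon bound to an aromatic carbon. Among the compounds with values here, no measured pair shows this change, so the step from compound 2 to compound 3 is expected to be small, in no firm direction, and likely to stay within the scatter: a 1.1-fold higher number from compound 2 to compound 3 (0.05 log units; within the scatter). Compound 3 is therefore estimated at 400 nM, with a range from 150 nM to 1100 nM.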

Compound 3, half-maximal inhibitory concentration: 600 nM
Compound 3: middle estimate off by 1.5-fold (0.18 log units), on the low side; the range from low to high includes it.
By their numbers in this assay, from the lowest: compounds 2 and 3 (each within the scatter of the next); then compound 1.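

Within the data shown here, compound 2 and compound 3 are the only pair here that differ in one place, and in this assay going from 2-hydroxyethyl to hydroxymethyl gives a 1.7-fold higher number from compound 2 to compound 3 (0.22 log units; within the scatter) and thus no real change. At this position, then, the chain can lose one carbon while keeping its hydroxy group without a change that stands out from the scatter. No available measurement gives a reason for this.

From the compounds shown here alone, both compounds carry a hydroxy group, so whether it matters remains open. So does the outcome with a longer chain, an amine or a carboxylic acid here.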